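The source may report more compounds than this note shows. Statements on the series, on what has been measured and on what is new or still open speak of the compounds shown alone.

- compound 1 `COc1ccc(-c2cc3c(OC)cc(OC)cc3n(CC#N)c2=O)cc1`: 10000 nM
- compound 2 `COc1ccc(-c2cc3c(OC)cc(OC)cc3n(CC(=O)O)c2=O)cc1`: 10000 nM

Both values come from a functional assay on T47D cells (Homo sapiens) for cytotoxicity, read by colorimetric assay and MTT assay; on this read-out higher numbers stand for weaker inhibition and lower numbers for stronger inhibition. In this assay compound 2 gives 10000 nM, level with compound 1 at 10000 nM, so the two compounds cannot be told apart on these numbers.

The next compound is compound 3 `COC(=O)CCn1c(=O)c(-c2ccc(OC)cc2)cc2c(OC)cc(OC)cc21`, which keeps the shared core and alters only the side chain: (methoxycarbonyl)methyl in place of carboxy on a saturated chain carbon bound to an aromatic nitrogen. In words, this is (methoxycarbonyl)methyl in place of carboxy on a saturated chain carbon bound to an aromatic nitrogen. Cut one bond further out, the same difference reads carboxymethyl to 2-(methoxycarbonyl)ethyl.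

For the measured compounds named here, only one measured step bears on this place, no change at the digits printed from compound 1 to compound 2 (within the scatter), where carboxy replaced cyano. Going by the values given here, that single step showed no movement, and no measured compound yet shows what an ester or a longer chain does here. The evidence therefore points to no shift in either direction, though only weakly, so the range must stay wide. The estimated step is no change at the digits printed from compound 2 to compound 3 (within the scatter). In this assay the expected value for compound 3 is 10000 nM, with an estimated range from 3000 nM to 30000 nM.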

Compound 3, half-maximal inhibitory concentration: 10000 nM
Estimate against measurement, compound 3: no gap at the digits printed, and the stated range covers the measured number.
By their numbers in this assay, from the lowest: compounds 1, 2 and 3 (each within the scatter of the next).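

In this assay, the swap of carboxy for (methoxycarbonyl)methyl on a saturated chain carbon bound to an aromatic nitrogen gives no change at the digits printed from compound 2 to compound 3 (within the scatter), and the swap of cyano for the same group gives no change at the digits printed from compound 1 to compound 3 (within the scatter), so neither step separates the compounds. This place has now carried a nitrile, a carboxy group and an ester on a longer chain, and the read-out stays level across all of them, even with carboxymethyl changed to 2-(methoxycarbonyl)ethyl and the one hydrogen-bond donor of carboxy replaced by none. No measurement shown here offers an explanation for this flat result.

All three compounds share one value, so they do not show whether any change at this place can move the number at all, or whether the side chain matters little on this core. On these data alone, an amine, an amide or a still longer chain at this place remains open, as does replacing the methoxy groups on the shared core with other groups.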